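Solubility notes: phenoxy in place of phenylcarbamoyl

The source may hold more compounds than are shown below. What is called first, only, known or untested is meant among the compounds shown, and "the series" means these compounds.

Compounds measured in a physicochemical assay for solubility, read by LC-MS, in phosphate buffer, with a stated time of 24 h, at pH 7.4; a higher number here means a more soluble compound, a lower number a less soluble compound:
compound 1, `CN(c1ccn(C)n1)c1cnc(NCc2c(F)ccc3c2CCO3)c2cn[nH]c(=O)c12`, gives 12000 nM
compound 2, `O=C1CCCN1c1cnc(NCc2c(F)ccc3c2CCO3)n2cnnc12`, gives 640000 nM
compound 3, `O=C(Nc1ccccc1)c1cnc(NCc2c(F)ccc3c2CCO3)n2cnnc12`, reaches only a limit of the assay, < 1000 nM

Compound 3 therefore stands at the limit, where one of the three values sits (the limit of < 1000 nM in this assay, at which 1 of the 3 values shown sits), and no number is known for it. The one measured step among these compounds is an at least 640-fold lower number from compound 2 to compound 3 (2.80 log units; beyond the scatter); it concerns the arrival of the phenylcarbamoyl group, not the change now considered. Compound 4, `Fc1ccc2c(c1CNc1ncc(Oc3ccccc3)c3nncn13)CCO2`, differs from compound 3 by phenoxy in place of phenylcarbamoyl on an aromatic carbon. For the measured compounds named here, no measured step covers a phenoxy group, so a step of an at least 1.5-fold higher number from compound 3 to compound 4 (0.17 log units; that floor lies within the scatter) is expected only loosely, with wide uncertainty. Compound 4 is estimated at 1500 nM, between 400 nM and 8000 nM, and a repeat of a limit-only result is quite possible.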

Compound 4, solubility: 8000 nM
Compound 4: middle estimate off by 5.3-fold (0.73 log units), on the low side; the range from low to high includes it.
By their numbers in this assay, from the lowest: compounds 4 and 1 (each within the scatter of the next); then compound 2. At a limit, below all of these: compound 3.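

In this assay, a second change at this aromatic carbon now has a readable result: phenoxy in place of phenylcarbamoyl gives an at least 8.0-fold higher number from compound 3 to compound 4 (0.90 log units; beyond the scatter). Compound 3 holds only a limit of the assay, so that step is a floor: the limit of < 1000 nM in this assay, at which 1 of the 4 values shown sits. Phenoxy does not return the number to the level of 2-oxopyrrolidin-1-yl, with an 80-fold lower number from compound 2 to compound 4 (1.90 log units; beyond the scatter).

From the compounds shown here alone, whether an amine, a carboxylic acid or a longer chain on this carbon would come closer to compound 2 stays open. These compounds also cannot separate the loss of the amide hydrogen from the loss of the carbonyl.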